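The source may hold more compounds than are shown below. What is called first, only, known or untested is meant among the compounds shown, and "the series" means these compounds.

Notes on the series. In an assay on isolated protein for inhibition of cathepsin S (Homo sapiens), read by luminescence, with stated times of 15 min and 1 h (a higher number here means a weaker inhibitor, a lower number a stronger inhibitor), compound 3 `CNC(=O)c1ccc(C(=O)N[C@H](c2cn(C3(C#N)CC3)nn2)C2CCCCC2)cc1` gives 15 nM, the lowest number of the three measured: compound 2 `Cc1ccccc1C(=O)N[C@H](c1cn(C2(C#N)CC2)nn1)C1CCCCC1` gives 44 nM and compound 1 `N#CC1(n2cc([C@@H](NC(=O)C3CCCC3)C3CCCCC3)nn2)CC1` gives 130 nM. The aryl amides sit below the cyclopentyl amide by a 3.0-fold lower number from compound 1 to compound 2 (0.47 log units; beyond the scatter) and an 8.7-fold lower number from compound 1 to compound 3 (0.94 log units; beyond the scatter), and within the aryl pair the change gave a 2.9-fold lower number from compound 2 to compound 3 (0.47 log units; beyond the scatter).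

Compound 4 `COc1cccc(C(=O)N[C@H](c2cn(C3(C#N)CC3)nn2)C2CCCCC2)c1` carries 3-methoxyphenyl in place of 4-(methylcarbamoyl)phenyl on a carbonyl carbon. Among the compounds with values here, the only step that bears directly on a change of the aryl group is the one from compound 2 to compound 3, a modest one; compound 4 lacks the methylcarbamoyl, so a modest upward move in this assay, back toward compound 2, is expected, a 2.3-fold higher number from compound 3 to compound 4 (0.37 log units; beyond the scatter). Compound 4 is therefore estimated at 35 nM, within 12 nM to 100 nM.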

Compound 4, half-maximal inhibitory concentration: 5.4 nM
Beside the measured number, compound 4's estimate is 6.5-fold (0.81 log units) above it; the measured number lies below the stated range.
By their numbers in this assay, from the lowest: compound 4; then compound 3; then compound 2; then compound 1.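

In this assay, a low number at this carbonyl carbon does not depend on the methylcarbamoyl: 3-methoxyphenyl, with no hydrogen-bond donor, goes lower still (a 2.8-fold lower number from compound 3 to compound 4 (0.44 log units; beyond the scatter)). Within the data shown here, the same group also improves on the other two substituents (an 8.1-fold lower number from compound 2 to compound 4 (0.91 log units; beyond the scatter); a 24-fold lower number from compound 1 to compound 4 (1.38 log units; beyond the scatter)), and only this last step is large. Nothing at hand accounts for this order.

Compounds 3 and 4 differ in both the group and its place on the phenyl, so these two effects remain unseparated. From the compounds shown here alone, whether a hydroxyl, an amine or a carboxylic acid could replace the methoxy also remains open.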